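A few compounds are considered here, and "the series" means these few. Any claim that something is new, unique, unknown or untested is made for them only; others in the source may bear on it.

Measured so far:
compound 1 `Cc1ccc(NC(=O)c2ccc(Br)cc2OCCCCn2ccnc2)cc1Nc1nccc(-c2cccnc2)n1` — 66100 nM
compound 2 `Cc1ccc(NC(=O)c2ccc([N+](=O)[O-])c(OCCCCn3ccnc3)c2)cc1Nc1nccc(-c2cccnc2)n1` — 25000 nM

For the measured compounds named here, in a functional assay on K562 cells (Homo sapiens) for cytotoxicity, read by XTT assay, with a stated time of 24 h (on this read-out higher numbers stand for weaker inhibition and lower numbers for stronger inhibition), compound 2 holds the lowest of the two numbers; compound 1, its only neighbour, lies beyond the scatter above it. Compound 3 `COc1ccc(C(=O)Nc2ccc(C)c(Nc3nccc(-c4cccnc4)n3)c2)cc1OCCCCn1ccnc1` is not yet measured. It differs from compound 2 in one place: methoxy in place of nitro on an aromatic carbon. Going by the values given here, no measured pair covers this change, so nothing measured points in either direction. The change is expected to give a 1.6-fold higher number from compound 2 to compound 3 (0.20 log units; within the scatter) in this assay, a small step if any, likely within the scatter. Compound 3 is estimated at 40000 nM, with a range of 12000 nM to 130000 nM.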

Compound 3, half-maximal inhibitory concentration: 10100 nM
Compound 3: the middle estimate sits 4.0-fold (0.60 log units) above what was measured, outside the stated range (below it).
By their numbers in this assay, from the lowest: compound 3; then compound 2; then compound 1.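

For the compounds shown here, at the aromatic carbon ortho to a 4-(1H-imidazol-1-yl)butoxy group and para to a large group, methoxy in place of nitro gives in this assay a 2.5-fold lower number from compound 2 to compound 3 (0.39 log units; beyond the scatter), the first single-place step. This position therefore responds to the group it carries, and methoxy gives the lower number of this pair. Nothing measured accounts for the step. From the compounds shown here alone, an amine or a carboxylic acid at this carbon remains open, so one step cannot set a trend across groups.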